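The source may report more compounds than this note shows. Statements on the series, on what has been measured and on what is new or still open speak of the compounds shown alone.

Measured so far in a functional assay on HEK293 cells for positive allosteric modulation of metabotropic glutamate receptor 5 (Homo sapiens), read by FLIPR and calcium flux; a lower number here means that less compound is needed, a higher number that more compound is needed for the effect:

compound 1, `O=C1c2ccc(C#Cc3cccc(Cl)c3)nc2CCN1C1CCCCC1` — 171 nM
compound 2, `O=C1c2ccc(C#Cc3cccnc3)nc2CCN1C1CCCCC1` — 387 nM

Compound 2 stands at the higher of the two numbers in this assay; its nearest neighbour is compound 1, and the change from one to the other is a single swap on the triple-bonded carbon, giving a 2.3-fold higher number from compound 1 to compound 2 (0.35 log units; beyond the scatter). Compound 3, `O=C1c2ccc(C#Cc3cccs3)nc2CCN1C1CCCCC1`, has not yet been measured. It differs from compound 2 in one place: thiophen-2-yl in place of pyridin-3-yl on a triple-bonded carbon. Among the measured compounds shown here, the only measured step that bears on this position is the one from compound 1 to compound 2, where the group on the triple-bonded carbon was exchanged and the number rose by a modest amount. Compound 3 is a second exchange at the same place, so a step of similar, modest size is expected in this assay, with the direction not fixed by the two numbers available. Since compound 1 sits lower and compound 2 higher, compound 3 is estimated to land between them or near compound 2, meaning a step of a 1.4-fold lower number from compound 2 to compound 3 (0.16 log units; within the scatter). Compound 3 is thus expected to give about 270 nM, within a range from 110 nM to 700 nM.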

Compound 3, half-maximal effective concentration: 13 nM
For compound 3 the middle estimate is 21-fold (1.32 log units) above the measured one; the whole stated range lies above it.
By their numbers in this assay, from the lowest: compound 3; then compound 1; then compound 2.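

In this assay, putting thiophen-2-yl in place of pyridin-3-yl on the triple-bonded carbon gives a 30-fold lower number from compound 2 to compound 3 (1.47 log units; beyond the scatter), and putting it in place of 3-chlorophenyl gives a 13-fold lower number from compound 1 to compound 3 (1.12 log units; beyond the scatter). Both steps are large, whereas the only step previously available at this place, a 2.3-fold higher number from compound 1 to compound 2 (0.35 log units; beyond the scatter), was modest, so the group here can move the number much further than the exchange of one six-membered aromatic ring for another had shown, and the one five-membered aromatic ring in the set gives the lowest number of the three. The data shown offer no explanation for the size of this drop.

The change from pyridin-3-yl to thiophen-2-yl alters ring size and hetero atom together, so these compounds do not separate the contribution of the five-membered ring from that of the sulfur, and a furan-2-yl or thiophen-3-yl group at the same place would be needed to tell them apart. The cyclohexyl group is also the same in all three compounds, which leaves open whether the low number would hold with a cyclopentyl or benzyl group in its stead.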